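Amino and Thiophene Swaps in a Nucleoside Series

This account rests on a few compounds, and the source may have more. Where it says the series, first, only, none or still open, it means among the compounds named here.

The study concerns four nucleoside analogues built on one shared core. Compound 1 `COc1ncnc2c1c(-c1ccsc1)cn2[C@@H]1O[C@H](CO)[C@@H](O)[C@H]1O` carries a thiophen-3-yl group and a hydrogen on the six-membered ring; in a functional assay on HepG2 cells (Homo sapiens) for antiproliferative activity, read by XTT assay, with a stated time of 72 h (on this read-out lower numbers stand for stronger inhibition and higher numbers for weaker inhibition), compound 1 gives 430 nM. Compound 2 `COc1nc(N)nc2c1c(-c1ccsc1)cn2[C@@H]1O[C@H](CO)[C@@H](O)[C@H]1O` differs from compound 1 by amino in place of hydrogen on an aromatic carbon. In this assay compound 2 gives only a limit of the assay, > 20000 nM. This change produces an at least 46-fold higher number from compound 1 to compound 2 (1.66 log units; beyond the scatter), measured against (the limit of > 20000 nM in this assay, at which 1 of the 3 values shown sits). Compound 3 `COc1ncnc2c1c(-c1cccs1)cn2[C@@H]1O[C@H](CO)[C@@H](O)[C@H]1O` differs from compound 1 in its core by thiophen-2-yl in place of thiophen-3-yl on an aromatic carbon. In this assay compound 3 gives 13900 nM, so this swap alone yields a 32-fold higher number from compound 1 to compound 3 (1.51 log units; beyond the scatter).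

Compound 4 `COc1nc(N)nc2c1c(-c1cccs1)cn2[C@@H]1O[C@H](CO)[C@@H](O)[C@H]1O` has not yet been measured in this assay. It differs from compound 3 by amino in place of hydrogen on an aromatic carbon, the same change as that from compound 1 to compound 2, with surroundings described in the same words. Compound 4 is expected to be a markedly weaker inhibitor than compound 3, a step estimated as a 14-fold higher number from compound 3 to compound 4 (1.16 log units; beyond the scatter), because compound 3 already gives 13900 nM and the amino substitution gave an at least 46-fold higher number from compound 1 to compound 2 (1.66 log units; beyond the scatter). The estimate for compound 4 in this assay is 200000 nM, with a plausible range from 30000 nM to 1000000 nM, and the assay will most likely report only a limit for compound 4.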

Compound 4, half-maximal inhibitory concentration: > 20000 nM
Compound 4 gave a limit, no number; the forecaster's own chance of this, stated with the estimate: 90%; the middle value is on the limit's open side.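

In this assay compound 4 reaches only a limit of the assay, not a number, and it shares that limit with compound 2: the limit of > 20000 nM in this assay, at which 2 of the 4 values shown sit.

Amino in place of hydrogen on an aromatic carbon, between two ring nitrogen atoms, therefore gives an at least 1.4-fold higher number from compound 3 to compound 4 (0.15 log units; that floor lies within the scatter), which does not establish on the core of compound 3 a change beyond the usual scatter. Set beside the earlier step, this shows that the change leaves no measured number on either core, but it does not show that the change has the same size on both, nor that its size differs: the same change on two cores in this assay, an at least 46-fold higher number (1.66 log units; beyond the scatter) from compound 1 to compound 2 and an at least 1.4-fold higher number (0.15 log units; that floor lies within the scatter) from compound 3 to compound 4; the limit leaves it open whether they differ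

From the compounds shown here alone, the step between compound 2 and compound 4, thiophen-2-yl in place of thiophen-3-yl, cannot be read, with a limit on both sides, so it remains open whether the position of attachment of the thiophene still matters once the amino group is present. The compounds shown also leave open how a methylamino group, a hydroxyl group or a methyl group on the same carbon would read on either core, and whether any of these would keep a measurable number in this assay.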